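A halogen swap and its expected effect on cytotoxicity

This account rests on a few compounds, and the source may have more. Where it says the series, first, only, none or still open, it means among the compounds named here.

Among the measured compounds shown here, compound 2 `COC(=O)c1cccc(Cl)c1OC(=O)COc1cc(O)c2c(=O)cc(-c3ccccc3)oc2c1` holds the only plain number in this small set: in an ADME assay on cells (T-cell, Mus musculus, strain BALB/c) for cytotoxicity, read by MTT assay, with a stated time of 48 h (a higher number here means that more compound is tolerated, a lower number that less compound is tolerated), compound 2 gives 366000 nM. Compound 1 `COC(=O)c1cc(Cl)ccc1OC(=O)COc1cc(O)c2c(=O)cc(-c3ccccc3)oc2c1` reached a limit of the assay, since compound 1 gives > 436000 nM in this assay. For the measured compounds named here, the single measured step, an at least 1.1-fold lower number from compound 1 to compound 2 (0.07 log units; that floor lies within the scatter), exchanges the 4-chloro-2-(methoxycarbonyl)phenyl for the 2-chloro-6-(methoxycarbonyl)phenyl and stays within the scatter; the position of compound 1 is fixed only by the limit of > 436000 nM in this assay, at which 1 of the 2 values shown sits. Compound 3 `COC(=O)c1ccc(Br)cc1OC(=O)COc1cc(O)c2c(=O)cc(-c3ccccc3)oc2c1` has not yet been measured. It differs from compound 2 by a group of 11 heavy atoms (8 carbon, 2 oxygen, 1 bromine; one six-membered aromatic ring of carbon only) in place of a group of 11 heavy atoms (8 carbon, 2 oxygen, 1 chlorine; one six-membered aromatic ring of carbon only), on an oxygen next to a carbonyl group. Going by the values given here, only the step from compound 1 to compound 2 bears on such a change on this oxygen, and it was small, so no step beyond the scatter is expected in this assay. Compound 3 is therefore estimated at 400000 nM, with a range from 200000 nM to 800000 nM, an expected step of a 1.1-fold higher number from compound 2 to compound 3 (0.04 log units; within the scatter).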

Compound 3, half-maximal cytotoxic concentration: 326000 nM
For compound 3 the middle estimate is 1.2-fold (0.09 log units) above the measured one, and the stated range covers the measured number.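

With the bromine-bearing group on this oxygen, a 1.1-fold lower number from compound 2 to compound 3 (0.05 log units; within the scatter) is all that this assay shows, so compound 2 and compound 3 cannot be told apart here, and the group with bromine fits the same range as the one with chlorine. The comparison with the other chlorine-bearing group gives an at least 1.3-fold lower number from compound 1 to compound 3 (0.12 log units; that floor lies within the scatter), which is only a floor and does not separate the two groups either. Compound 1 stands at a limit of the assay, not at a number: the limit of > 436000 nM in this assay, at which 1 of the 3 values shown sits.

Going by these compounds, all three groups carry a halogen and a methoxycarbonyl on a phenyl ring, so the effect of an amine or a carboxylic acid on that ring remains open. Also open, on these data alone, is how a longer chain on this oxygen would read in this assay, and whether changes to the shared core would matter more.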